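Amide variation on the shared core: moving off the aryl ring

This account rests on a few compounds, and the source may have more. Where it says the series, first, only, none or still open, it means among the compounds named here.

Two amides on the shared core have been measured in an assay (strain Wistar) for displacement of a labelled ligand from adenosine receptor A1 (Rattus norvegicus), read by scintillation counting; on this read-out higher numbers stand for weaker inhibition and lower numbers for stronger inhibition. Compound 1 `O=C(Nc1nc(-c2ccccc2)nc2c1nnn2Cc1ccccc1)c1cccc([N+](=O)[O-])c1` gives 77 nM in this assay. Compound 2 `O=C(Nc1nc(-c2ccccc2)nc2c1nnn2Cc1ccccc1)c1ccccc1F` gives 40 nM. Among the measured compounds shown here, the single change between them, 2-fluorophenyl in place of 3-nitrophenyl on a carbonyl carbon, gave a 1.9-fold lower number from compound 1 to compound 2 (0.28 log units; within the scatter), so the two numbers cannot be told apart. Compound 2 therefore holds the lowest of the two numbers, with compound 1 a short way above it and inside the scatter.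

Compound 3 `O=C(Nc1nc(-c2ccccc2)nc2c1nnn2Cc1ccccc1)C1CCCCC1` is not yet measured. It differs from compound 2 by cyclohexyl in place of 2-fluorophenyl on a carbonyl carbon. For the measured compounds named here, the only measured step swapped one six-membered aromatic ring for another and stayed within the scatter; no measured compound carries a non-aromatic ring on the carbonyl carbon, so nothing bears directly on this change. The step is expected to be a 2.3-fold higher number from compound 2 to compound 3 (0.35 log units; beyond the scatter), with the direction open. For compound 3 the estimate in this assay is 90 nM, with a range from 20 nM to 400 nM.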

Compound 3, inhibition constant: 12 nM
The estimate for compound 3 lay 7.5-fold (0.88 log units) above the measured number; measured number outside the range, below it.
By their numbers in this assay, from the lowest: compound 3; then compounds 2 and 1 (each within the scatter of the next).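

In this assay, among the compounds shown here, the group on the carbonyl carbon need not be aromatic: cyclohexyl in place of 2-fluorophenyl gave a 3.3-fold lower number from compound 2 to compound 3 (0.52 log units; beyond the scatter) and cyclohexyl in place of 3-nitrophenyl gave a 6.4-fold lower number from compound 1 to compound 3 (0.81 log units; beyond the scatter) and both steps lie beyond the scatter, whereas the one earlier step, between two aromatic rings, stayed inside it. For the compounds shown here, this position therefore does respond to the group placed on it, and compound 3, the only compound here with a non-aromatic ring, holds the lowest number of the three, though a single compound shows no trend. No available data account for the difference between cyclohexyl and the two aromatic rings.

From the compounds shown here alone, it remains open whether the lower number belongs to the six-membered ring specifically or extends to other non-aromatic groups on the carbonyl carbon, such as cyclopentyl, tert-butyl or an open n-butyl chain. Also open, going by these compounds, is how the position responds to a ring carrying nitrogen, such as piperidine, or to a carboxylic acid or an amine added to the cyclohexyl ring.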